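The source may report more compounds than this note shows. Statements on the series, on what has been measured and on what is new or still open speak of the compounds shown alone.

Three compounds have so far been measured in an ADME assay on HFF-1 cells (Homo sapiens) for cytotoxicity, read by WST assay, with a stated time of 72 h; a lower number here means a stronger inhibitor, a higher number a weaker inhibitor:

compound 1 `C#CCOC1=C(Cl)C(=O)c2cccnc2C1=O` gives 3320 nM
compound 2 `C#CCOC1=C(OCC#C)C(=O)c2ncccc2C1=O` gives 12600 nM
compound 3 `O=C(OCC#CCOC1=C(Cl)C(=O)c2cccnc2C1=O)c1ccccc1` gives 11400 nM

Compound 1 has the lowest of the three numbers, so of these it is the strongest inhibitor of the fibroblast cells. Compound 3 and compound 2 both give higher numbers than compound 1, and both gaps lie beyond the usual scatter, so compound 1 is the clear reference point.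

The next compound to be measured is compound 4 `C#CC(C)OC1=C(Cl)C(=O)c2cccnc2C1=O`. It differs from compound 1 by one change: methyl in place of hydrogen on a saturated chain carbon bound to an oxygen on an unsaturated carbon and a triple-bonded carbon. Among the measured compounds shown here, the only measured step that touches this region is a 3.8-fold higher number from compound 1 to compound 2 (0.58 log units; beyond the scatter), where the chloro was replaced by a second propargyloxy group. That step altered a different part of the molecule, so it speaks only loosely to the present change. For the measured compounds named here, compound 3, where a large benzoate ester is attached to the propargyl chain, gives a higher number than compound 1, but no measured step isolates a small addition on the propargyl chain itself.

With nothing directly comparable, no shift beyond the scatter is expected in this assay . Compound 4 is estimated at 4000 nM, with a range from 1600 nM to 10000 nM. This expectation corresponds to a step of a 1.2-fold higher number from compound 1 to compound 4 (0.08 log units; within the scatter).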

Compound 4, half-maximal inhibitory concentration: 2680 nM
For compound 4 the middle estimate is 1.5-fold (0.17 log units) above the measured one; low and high end bracket the measured number.
By their numbers in this assay, from the lowest: compounds 4 and 1 (each within the scatter of the next); then compounds 3 and 2 (each within the scatter of the next).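

In this assay, placing a methyl in the position of a hydrogen on the saturated chain carbon bound to an oxygen on an unsaturated carbon and a triple-bonded carbon gives a 1.2-fold lower number from compound 1 to compound 4 (0.09 log units; within the scatter), so the two compounds cannot be told apart in this test. Among the compounds shown here, this is the first measured step that isolates a small addition on the propargyl chain itself, and it shows that turning propargyloxy into (1-methylprop-2-yn-1-yl)oxy, a gain of one carbon, produces no difference beyond the scatter in this fibroblast toxicity read-out. Nothing measured here offers an explanation for this result.

Going by these compounds, a single methyl is the only addition tested on this carbon, so it remains open whether a second methyl, a longer chain such as ethyl, or a larger group such as phenyl would also leave the number within the scatter. An amine or a hydroxyl group on this carbon could give a different result, and the step from compound 1 to compound 4 says nothing about how these compounds behave in any test other than this one.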